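The compounds below may be only part of what the source reports. "The series", "measured", "known", "first", "only" and "open" are said of these compounds alone.

Going by the values given here, in a functional assay on HT-29 cells (Homo sapiens) for inhibition, read by sulforhodamine B assay, with a stated time of 48 h (on this read-out lower numbers stand for stronger inhibition of growth and higher numbers for weaker inhibition of growth), compound 2 `c1ccc(COc2cccc(NC3=NCCO3)c2)cc1` gives 800 nM, the lowest of the three numbers so far and beyond the scatter from both of the others. Compound 4 `O=C(CCl)NC(=O)Nc1cccc(OCc2ccccc2)c1` differs from it as follows: a group of 7 heavy atoms (3 carbon, 1 nitrogen, 2 oxygen, 1 chlorine; no ring) in place of a group of 5 heavy atoms (3 carbon, 1 nitrogen, 1 oxygen; one five-membered non-aromatic ring with 2 hetero atoms), on a nitrogen on an aromatic ring. Among the compounds with values here, no measured step covers this change. Compound 1 `c1cc2c(cc1NC1=NCCO1)CCC2` at 4900 nM and compound 3 `O=C(CCl)NC(=O)Nc1ccc2c(c1)CCC2` at 7000 nM lie within the scatter of each other, so the step in this assay is expected to stay within the scatter, if anything toward a slightly higher number. The estimated step is a 1.4-fold higher number from compound 2 to compound 4 (0.14 log units; within the scatter). For compound 4 the expected value is 1100 nM, with an estimated range of 400 nM to 3200 nM.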

Compound 4, concentration for 50% growth inhibition: 6500 nM
For compound 4 the middle estimate is 5.9-fold (0.77 log units) below the measured one, and the stated range ends below it.
By their numbers in this assay, from the lowest: compound 2; then compounds 1, 4 and 3 (each within the scatter of the next).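

In this assay swapping the five-membered non-aromatic ring on the nitrogen for ((chloromethyl)carbonyl)carbamoyl gives an 8.1-fold higher number from compound 2 to compound 4 (0.91 log units; beyond the scatter) and so loses growth inhibition. With the core of compound 1 the same exchange separates nothing, as compound 1 at 4900 nM and compound 3 at 7000 nM lie within the scatter of each other, so in these two pairs the size of the change depends on the core. No measurement available here bears on the reason for this difference.

Open, from the compounds shown here alone, is whether the chlorine matters to the loss or the rest of the entering group does. The compounds shown do not say how a plain acetyl group in place of the chloromethylcarbonyl part would read.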